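The source may hold more compounds than are shown below. What is called first, only, known or untested is meant among the compounds shown, and "the series" means these compounds.

Measured so far:
- compound 1 `Cc1c(OCCCCOc2cccc(C(=O)O)c2)ccc(C(=O)CC(C)C)c1O`, 69.9%
- compound 2 `CC(=O)c1ccc(OCCCCOc2ccc(C(=O)O)cc2C)c(C)c1O`, 25.4%

In an assay on HEK293 cells for positive allosteric modulation of metabotropic glutamate receptor 3 (Rattus norvegicus), read by thallium flux, with a stated time of 2.5 min (a lower number here means a smaller maximal response, a higher number a larger maximal response), compound 2 gives the lowest of the two numbers; compound 1 stands a good deal higher, beyond the usual scatter. The two compounds differ in more than one place, so the gap between them cannot be laid on a single change.

Compound 3 `Cc1cc(C(=O)O)ccc1OCCCCOc1ccc(C(=O)CC(C)C)c(O)c1C` is not yet measured. It differs from compound 2 in one place: isopropyl in place of hydrogen on a saturated chain carbon bound to a carbonyl carbon. Among the compounds with values here, the isobutylcarbonyl that enters is the same ketone that compound 1 carries, which is the only compound here with a high maximal response. That is a loose hint only, since compound 1 and compound 2 also differ elsewhere.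

For compound 3 a rise is expected in this assay, larger than the scatter, but not the full distance to compound 1: the step of a number 24.6 percentage points higher from compound 2 to compound 3 (beyond the scatter) is the estimate, resting on compound 1 at 69.9% sharing the isobutylcarbonyl. Compound 3 is therefore estimated at 50%, with a range from 28% to 75%.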

Compound 3, largest response reached (reported as percent of maximum), in percent of the reference or control that the assay uses: 42.1%
The estimate for compound 3 lay 7.9 percentage points above the measured number; the measured number falls inside the stated range.
By their numbers in this assay, from the lowest: compound 2; then compound 3; then compound 1.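

In this assay, isopropyl in place of hydrogen on a saturated chain carbon bound to a carbonyl carbon, which turns acetyl into isobutylcarbonyl, gives a number 16.7 percentage points higher from compound 2 to compound 3 (beyond the scatter). Within the data shown here, this is the first reading of that position alone, and it shows that the group on the ketone moves the maximal response by more than the scatter while the rest of the molecule stays fixed. With the isobutylcarbonyl held constant, 4-carboxy-2-methylphenyl in place of 3-carboxyphenyl on an oxygen on a saturated carbon gives a number 27.8 percentage points lower from compound 1 to compound 3 (beyond the scatter), so the acid-bearing end also moves the response, and the ketone group alone does not set its level; no measurement on hand explains either step.

Still open, on these data alone, is how the response runs at the ketone beyond isobutylcarbonyl, for example with a longer chain or a cyclohexyl group in place of the isopropyl. The change at the other end also joins a different place for the carboxylic acid with an added methyl, so the share of each remains unresolved, as does the outcome of replacing the carboxylic acid with a tetrazole.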